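This account rests on a few compounds, and the source may have more. Where it says the series, first, only, none or still open, it means among the compounds named here.

Compound 1 `CCOc1ccccc1-c1ncc(C(=O)O)c(=O)[nH]1` and compound 2 `CCCOc1ccccc1-c1ncc(C(=O)O)c(=O)[nH]1` were examined in a functional assay on the whole organism (strain Sprague-Dawley) for inhibition, with Rattus norvegicus as the target, with a stated time of 10 min; on this read-out lower numbers stand for an effect already at smaller amounts and higher numbers for an effect only at larger amounts of compound. Compound 1 gives 0.5 mg/kg and compound 2 gives 0.9 mg/kg; the step of a 1.8-fold higher number from compound 1 to compound 2 (0.26 log units; within the scatter) comes from methyl in place of hydrogen on a saturated chain carbon, two bonds along the chain from an oxygen on an aromatic ring. Compound 3 `CCOC(=O)c1cnc(-c2ccccc2OCC)[nH]c1=O` gives 2 mg/kg in this assay, the highest of the three numbers; its core differs from the core of compound 1 by ethyl in place of hydrogen on an oxygen next to a carbonyl group, a change that made the step of a 4.0-fold higher number from compound 1 to compound 3 (0.60 log units; beyond the scatter). Compound 4 `CCCOc1ccccc1-c1ncc(C(=O)OCC)c(=O)[nH]1` has not yet been measured in this assay; it differs from compound 3 by methyl in place of hydrogen on a saturated chain carbon, two bonds along the chain from an oxygen on an aromatic ring, the same change as that between compound 1 and compound 2. Compound 4 is expected to show a 1.8-fold higher number from compound 3 to compound 4 (0.26 log units; within the scatter), which rests on the step of a 1.8-fold higher number from compound 1 to compound 2 (0.26 log units; within the scatter). Compound 4 is thus estimated at 3.6 mg/kg, with a range from 1.5 mg/kg to 8 mg/kg.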

Compound 4, dose for 50% inhibition: 5 mg/kg
Estimate against measurement, compound 4: 1.4-fold (0.14 log units) below; low and high end bracket the measured number.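

In this assay, ethoxy to propoxy on the ester core gives a 2.5-fold higher number from compound 3 to compound 4 (0.40 log units; beyond the scatter), and this agrees with the same change on the core of compound 1: the same change on two cores in this assay, a 1.8-fold higher number (0.26 log units; within the scatter) from compound 1 to compound 2 and a 2.5-fold higher number (0.40 log units; beyond the scatter) from compound 3 to compound 4, 1.4-fold (0.14 log units) apart, within the scatter of two such steps The ethyl in place of hydrogen on the oxygen next to a carbonyl group gives a 5.6-fold higher number from compound 2 to compound 4 (0.74 log units; beyond the scatter), which likewise agrees with its earlier counterpart: the same change on two cores in this assay, a 4.0-fold higher number (0.60 log units; beyond the scatter) from compound 1 to compound 3 and a 5.6-fold higher number (0.74 log units; beyond the scatter) from compound 2 to compound 4, 1.4-fold (0.14 log units) apart, within the scatter of two such steps Both changes thus carried over between these two cores without a gap beyond the scatter, but these four compounds show this for one set of cores only and do not explain it, nor do they show that it holds elsewhere in the series.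

The compounds shown leave open how a longer chain such as butoxy would behave on either core. They also leave open whether an amide in place of the ethyl ester would follow the same steps.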